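This account rests on a few compounds, and the source may have more. Where it says the series, first, only, none or still open, it means among the compounds named here.

The measured compounds:

Compound 1, `CCOC(=O)c1c(-c2cccc(OC)c2)[nH]c2cc(F)cc(F)c2c1=O`: in an ADME assay on HepG2 cells (Homo sapiens) for cytotoxicity, read by luminescence, with a stated time of 72 h (a lower number here means that less compound is needed, a higher number that more compound is needed for the effect), compound 1 gives > 21500 nM, which is a limit of the assay and not a number.

Compound 2, `CCOC(=O)c1c(-c2cccc(Oc3ccccc3)c2)[nH]c2cc(F)cc(F)c2c1=O`: in this assay compound 2 gives > 21500 nM, again a limit and not a number.

Compound 3, `CCOC(=O)c1c(-c2cccc(OC)c2)[nH]c2cc(OC)c(OC)cc2c1=O`: in this assay compound 3 gives > 21500 nM, also a limit and not a number.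

Compound 1 and compound 2 differ in one place, (phenyl in place of methyl on an oxygen on an aromatic ring). In this assay this change made a step that the two limits leave unreadable from compound 1 to compound 2, so its size cannot be read. What all three compounds share is the limit of > 21500 nM in this assay, at which 3 of the 3 values shown sit; none of them gave a number.

Compound 4, `CCOC(=O)c1c(-c2cccc(Oc3ccccc3)c2)[nH]c2cc(OC)c(OC)cc2c1=O`, is not yet measured. It differs from compound 3 by phenyl in place of methyl on an oxygen on an aromatic ring, the same change as from compound 1 to compound 2, at the same place. How the core of compound 3 differs from the core of compound 1 is not broken down here.

In this assay the expected step is a step that the limit leaves unreadable from compound 3 to compound 4, which rests on a step that the two limits leave unreadable from compound 1 to compound 2 and on (the limit of > 21500 nM in this assay, at which 3 of the 3 values shown sit), with nothing among the three compounds pointing away from the limit. For compound 4 the estimate is 30000 nM, expected between 15000 nM and 100000 nM, most likely again reported only as a limit.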

Compound 4, half-maximal effective concentration: > 21500 nM
Compound 4: no number, only a limit; the forecaster's own chance of this, stated with the estimate: 85%; the middle value is on the limit's open side.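

In this assay compound 4 gives > 21500 nM, a limit and not a number, so no size can be read for the step from compound 3 to compound 4. The result is the same across the series: the limit of > 21500 nM in this assay, at which 4 of the 4 values shown sit.

The compounds shown leave open what concentration each would need for the effect, and whether changing methoxy to phenoxy alters it on either core.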